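Piperidine nitrogen substituent and antagonism at the chemokine receptor

The source may report more compounds than this note shows. Statements on the series, on what has been measured and on what is new or still open speak of the compounds shown alone.

Three compounds of the series have numbers in a functional assay for antagonist activity at C-X-C chemokine receptor type 3 (Homo sapiens); on this read-out higher numbers stand for weaker inhibition and lower numbers for stronger inhibition. Compound 1 `CNC(=O)c1cnc(N2CCN(C3CCN(Cc4ccco4)CC3)[C@@H](C)C2)c(Cl)c1` gives 8100 nM, compound 2 `CNC(=O)c1cnc(N2CCN(C3CCN(Cc4cccs4)CC3)[C@@H](C)C2)c(Cl)c1` gives 1980 nM, and compound 3 `CNC(=O)c1cnc(N2CCN(C3CCN(C(F)(F)F)CC3)[C@@H](C)C2)c(Cl)c1` gives 63 nM. Compound 2 holds the second highest of the three numbers; its nearest neighbour is compound 1, with a 4.1-fold lower number from compound 1 to compound 2 (0.61 log units; beyond the scatter), and its furthest is compound 3, with a 31-fold lower number from compound 2 to compound 3 (1.50 log units; beyond the scatter). The third measured step, a 130-fold lower number from compound 1 to compound 3 (2.11 log units; beyond the scatter), confirms that the group on the amine nitrogen in the ring decides the outcome in this series.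

Compound 4 `CNC(=O)c1cnc(N2CCN(C3CCN(Cc4ccc(F)cc4Cl)CC3)[C@@H](C)C2)c(Cl)c1` is not yet measured. It differs from compound 2 in that position: 2-chloro-4-fluorophenyl in place of thiophen-2-yl on a saturated chain carbon bound to an amine nitrogen in a ring. Both measured steps that touch this position bear on it. The exchange between two five-membered aromatic rings in a 4.1-fold lower number from compound 1 to compound 2 (0.61 log units; beyond the scatter) was modest, whereas the move to trifluoromethyl in a 31-fold lower number from compound 2 to compound 3 (1.50 log units; beyond the scatter) was large. Neither step shows a six-membered aromatic ring of carbon only with halogen, so the direction for compound 4 is open; the step of a 1.3-fold lower number from compound 2 to compound 4 (0.12 log units; within the scatter) is expected to be small and may well lie within the scatter. For compound 4 the estimate in this assay is 1500 nM, with a range from 300 nM to 8000 nM.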

Compound 4, half-maximal inhibitory concentration: 58 nM
For compound 4 the middle estimate is 26-fold (1.41 log units) above the measured one; measured number outside the range, below it.
By their numbers in this assay, from the lowest: compounds 4 and 3 (each within the scatter of the next); then compound 2; then compound 1.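

Notes on the group on the piperidine nitrogen, read in this assay: an aromatic ring on the saturated chain carbon bound to an amine nitrogen in a ring does not in itself go with the high numbers of the two five-membered rings. 2-Chloro-4-fluorophenyl in place of thiophen-2-yl gives a large step (a 34-fold lower number from compound 2 to compound 4 (1.53 log units; beyond the scatter)), and in place of furan-2-yl an equally large one (a 140-fold lower number from compound 1 to compound 4 (2.15 log units; beyond the scatter)), while the exchange of one five-membered ring for the other was only modest. Trifluoromethyl is also not alone in reaching the low end of the series, since 2-chloro-4-fluorobenzyl on the amine nitrogen in a ring stands level with it (a 1.1-fold lower number from compound 3 to compound 4 (0.04 log units; within the scatter)), and no measurement at hand accounts for any of these differences.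

Open, going by these compounds, is whether plain phenyl, or a phenyl carrying only the chlorine or only the fluorine, would keep the number of compound 4. Also open, on these data alone, is how an amine or a carboxylic acid on that ring, or a longer chain in place of the single chain carbon, would read in this assay.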